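The source may hold more compounds than are shown below. What is called first, only, known or untested is meant among the compounds shown, and "the series" means these compounds.

Values from a functional assay on L1210 cells (Mus musculus) for inhibition (on this read-out higher numbers stand for weaker inhibition and lower numbers for stronger inhibition), so far:
- compound 1 `C=CCNc1cccnc1/C=N/N=C(/N)S` gives > 10000 nM as a limit of the assay
- compound 2 `CCNc1ccc(/C=N/N=C(/N)S)nc1` gives 3400 nM
- compound 3 `C=CCNc1ccc(/C=N/N=C(/N)S)nc1` gives 4400 nM

Compound 3 at 4400 nM cannot be told apart from compound 2 at 3400 nM on these numbers. Compound 4 `CCCNc1ccc(/C=N/N=C(/N)S)nc1` carries ethyl in place of vinyl on a saturated chain carbon bound to a nitrogen on an aromatic ring, that is, allyl to propyl (ethyl in place of vinyl on a saturated chain carbon bound to a nitrogen on an aromatic ring). Within the data shown here, one measured step bears on this place: a 1.3-fold higher number from compound 2 to compound 3 (0.11 log units; within the scatter) with vinyl in place of methyl. Going by the small size of that step between compound 2 and compound 3, no change beyond the scatter is expected in this assay here. The estimated step is a 1.1-fold lower number from compound 3 to compound 4 (0.04 log units; within the scatter) and it should stay inside the scatter. Compound 4 is estimated at 4000 nM with an expected range from 1700 nM to 9000 nM in this test.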

Compound 4, half-maximal inhibitory concentration: 5100 nM
For compound 4 the middle estimate is 1.3-fold (0.11 log units) below the measured one; the measured number falls inside the stated range.
By their numbers in this assay, from the lowest: compounds 2, 3 and 4 (each within the scatter of the next). At a limit, above all of these: compound 1.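

Replacing allyl with propyl removes the double bond from the chain, yet this assay shows no change beyond the scatter, with a 1.2-fold higher number from compound 3 to compound 4 (0.06 log units; within the scatter). The added methyl of the propyl chain also stays small, with a 1.5-fold higher number from compound 2 to compound 4 (0.18 log units; within the scatter), so the ethyl, allyl and propyl chains cannot be told apart here. Nothing at hand gives a cause for these small steps. From the compounds shown here alone, it stays open whether a longer chain such as butyl, or a chain ending in an amine or a carboxylic acid, would still sit within the scatter of these three.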